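A few compounds are considered here, and "the series" means these few. Any claim that something is new, unique, unknown or untested is made for them only; others in the source may bear on it.

Measured so far in a functional assay on HCT-116 cells (Homo sapiens) for inhibition, read by MTT assay, with a stated time of 48 h; a lower number here means a stronger inhibitor, a higher number a weaker inhibitor:
- compound 1 `O=C(CSc1nnc(-c2ccncc2)n1-c1ccccc1)N/N=C/c1ccccc1`: 14700 nM
- compound 2 `O=C(CSc1nnc(-c2ccncc2)n1-c1ccccc1)N/N=C/c1ccccc1O`: 7060 nM

Compound 2 holds the lower of the two numbers in this assay; the step of a 2.1-fold lower number from compound 1 to compound 2 (0.32 log units; beyond the scatter) is modest but beyond the scatter. Compound 3 `O=C(CSc1nnc(-c2ccncc2)n1-c1ccccc1)N/N=C/c1ccc(O)c(O)c1` is not yet measured. It differs from compound 2 by 3,4-dihydroxyphenyl in place of 2-hydroxyphenyl on a carbon with a double bond to nitrogen. Within the data shown here, the only step that bears on this is a 2.1-fold lower number from compound 1 to compound 2 (0.32 log units; beyond the scatter), where a hydroxy entered; here a second hydroxy enters while the first is relocated, so the guide is thin. The step expected for compound 3 is a 1.4-fold lower number from compound 2 to compound 3 (0.15 log units; within the scatter), a modest lowering at best, possibly within the scatter. Compound 3 is therefore estimated at 5000 nM, with a range from 2000 nM to 14000 nM.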

Compound 3, half-maximal inhibitory concentration: 14700 nM
Beside the measured number, compound 3's estimate is 2.9-fold (0.47 log units) below it; the measured number lies above the stated range.
By their numbers in this assay, from the lowest: compound 2; then compounds 1 and 3 (each within the scatter of the next).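

In this assay, among these compounds, adding hydroxy groups to the aryl ring at this carbon does not lower the number in a simple way: 3,4-dihydroxyphenyl in place of 2-hydroxyphenyl gives a step in the opposite direction (a 2.1-fold higher number from compound 2 to compound 3 (0.32 log units; beyond the scatter)), and in place of phenyl it gives no step (no change at the digits printed from compound 1 to compound 3 (within the scatter)). Of the three groups at this place, only 2-hydroxyphenyl stands apart, and compound 3 does not share the lower number of compound 2. No evidence at hand accounts for this difference.

As far as these compounds go, it remains open whether the lower number of compound 2 depends on where the hydroxy sits or on how many hydroxy groups are present. From the compounds shown here alone, whether a methoxy group or an amine on the same phenyl ring would track compound 2 or compound 3 is also open.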